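A few compounds are considered here, and "the series" means these few. Any claim that something is new, unique, unknown or untested is made for them only; others in the source may bear on it.

Measured compounds in a functional assay on K562 cells (Homo sapiens) for inhibition, read by sulforhodamine B assay, with a stated time of 48 h; a lower number here means a stronger inhibitor of growth, a higher number a weaker inhibitor of growth:
- compound 1 `N#C/C(=C\N1CCN(C(=O)c2ccco2)C1=S)C(=O)Nc1ccc(Cl)cc1`: 16100 nM
- compound 2 `N#C/C(=C\N1CCN(C(=O)c2ccco2)C1=S)C(N)=O`: 9100 nM
- compound 3 `O=CN1CCN(c2ccc(Cl)cc2)C1=S`: 12900 nM

Compound 3 stands second highest of the three numbers in this assay; its nearest neighbour is compound 1, whose value differs from it only within the scatter, and its furthest is compound 2, also within the scatter. The three compounds therefore cannot be ordered against each other on these numbers.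

Going by the values given here, the only measured step, a 1.8-fold lower number from compound 1 to compound 2 (0.25 log units; within the scatter), is a change at an amide-type nitrogen of a different part of the molecule and was itself within the scatter. Among the compounds with values here, it does not touch the aromatic ring, so no measured step bears directly on the change to be considered here.

Compound 4 `O=CN1CCN(c2ccc(Cl)c(Cl)c2)C1=S` differs from compound 3 by chloro in place of hydrogen on an aromatic carbon. Within the data shown here, with no step on that ring, and the one available step lying within the scatter, the working expectation for this assay is no change beyond the scatter, with a wide range to reflect the absence of direct precedent.

Compound 4 is expected to give 11000 nM in this assay, within a range from 4500 nM to 27000 nM, corresponding to an expected step of a 1.2-fold lower number from compound 3 to compound 4 (0.07 log units; within the scatter).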

Compound 4, concentration for 50% growth inhibition: 13800 nM
For compound 4 the middle estimate is 1.3-fold (0.10 log units) below the measured one; the measured number falls inside the stated range.
By their numbers in this assay, from the lowest: compounds 2, 3, 4 and 1 (each within the scatter of the next).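

In this assay, going by these compounds alone, chloro in place of hydrogen on an aromatic carbon, ortho to a chloro group and meta to a group of 8 heavy atoms, gives a 1.1-fold higher number from compound 3 to compound 4 (0.03 log units; within the scatter), the first measured step on this ring and one that lies within the scatter. This position therefore accepts a second chloro with no readable change in growth inhibition, although that reading rests on a single pair and applies only to this position and this group. No available evidence bears on the result.

The compounds shown leave open whether a different group on this same aromatic carbon, such as an amine, a carboxylic acid or a longer chain, would move the number beyond the scatter, as chloro here does not. Also open, from the compounds shown here alone, is whether removing the existing chloro group from the ring, leaving hydrogen at that carbon, would produce a step beyond the scatter, or whether this part of the molecule can be changed freely in this assay.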